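Methyl in place of methoxy on a shared core

This account rests on a few compounds, and the source may have more. Where it says the series, first, only, none or still open, it means among the compounds named here.

Compound 1, `COc1ccc(-n2c(=O)n(Cc3cc4cc(Cl)ccc4n3CCCC#N)c3cnccc32)cc1OC`: > 50000 nM.
Compound 2, `CS(=O)(=O)CCCn1c(Cn2c(=O)n(CC3CC3)c3ccncc32)cc2cc(Cl)ccc21`: > 50000 nM.
Compound 3, `O=c1n(Cc2cc3ccncc3n2CCCCO)c2cnccc2n1C1CC1`: > 100000 nM.

These three compounds were tested in an ADME assay on HeLa cells (Homo sapiens) for cytotoxicity, read by ATP content, with a stated time of 3 days; a higher number here means that more compound is tolerated, a lower number that less compound is tolerated. For compound 1 the result is a limit of the assay rather than a number, (the limit of > 50000 nM in this assay, at which 2 of the 3 values shown sit). Compound 2 sits at that same limit. Compound 3 stands at a different limit, (the limit of > 100000 nM in this assay, at which 1 of the 3 values shown sits). All three values are thus limits, and none of the three is distinguished from the others by a number; where compound 1 stands can be said only as far as the limit allows.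

Compound 4, `COc1ccc(-n2c(=O)n(Cc3cc4cc(Cl)ccc4n3CCCC#N)c3cnccc32)cc1C`, has not yet been measured in this assay. It differs from compound 1 in one place: methyl in place of methoxy on an aromatic carbon. The change is small in what it removes and what it brings in, and the three measured compounds, differing far more widely from one another, all sit at a limit.

The step that the limit leaves unreadable from compound 1 to compound 4 is therefore expected to be none beyond the scatter. Compound 4 is expected to give 80000 nM, with a range from 40000 nM to 200000 nM, and most likely again only a limit of this assay.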

Compound 4, half-maximal cytotoxic concentration: > 50000 nM
Compound 4: a limit, no number; the forecaster's own chance of this, stated with the estimate: 85%; the middle value is on the limit's open side.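

In this assay compound 4 gives > 50000 nM, which is a limit of the assay and not a number. Compound 1 also stands at a limit, so no step between compound 1 and compound 4 can be read: the limit of > 50000 nM in this assay, at which 3 of the 4 values shown sit.

The compounds shown leave open how much of compound 1 or compound 4 is tolerated, and whether methyl in place of methoxy on an aromatic carbon changes that at all.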